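Phenyl to Benzyl Exchange in Jurkat Growth Inhibition

The source may hold more compounds than are shown below. What is called first, only, known or untested is meant among the compounds shown, and "the series" means these compounds.

Measured compounds and their values in a functional assay on Jurkat cells (Homo sapiens) for inhibition, read by CCK-8 assay, with a stated time of 48 h; a higher number here means a weaker inhibitor of growth, a lower number a stronger inhibitor of growth:
Compound 1 `Cc1ccccc1Nc1nc(Nc2ccccc2)ncc1Cl` gives > 100000 nM, which is a limit of the assay and not a number.
Compound 2 `Cc1ccccc1Nc1nc(NCc2ccccc2)ncc1Cl` gives > 100000 nM, again a limit rather than a number.
Compound 3 `CN1CCN(c2ccc(Nc3ncc(Cl)c(Nc4ccccc4)n3)nc2)CC1` gives > 100000 nM, once more a limit and not a number.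

The three measured compounds share a common pattern of change. Compound 1 and compound 2 differ only by benzyl in place of phenyl on a nitrogen on an aromatic ring. The step that the two limits leave unreadable from compound 1 to compound 2 cannot be read, as both compounds sit at the same limit. Compound 3 carries a different core; how its core differs from that of compound 1 is not broken down here. For the measured compounds named here, what unites all three is the limit of > 100000 nM in this assay, at which 3 of the 3 values shown sit, so no measured step among them has a readable size.

Compound 4 `CN1CCN(c2ccc(Nc3ncc(Cl)c(NCc4ccccc4)n3)nc2)CC1` has not yet been measured in this assay. It differs from compound 3 by benzyl in place of phenyl on a nitrogen on an aromatic ring, the same change that separates compound 1 from compound 2, made at the same kind of place. Since the earlier instance of that change left the readout at the limit on both sides, the step from compound 3 to compound 4 is expected to be small, close to a number no higher from compound 3 to compound 4 (the limit leaves the size open), and that expectation rests on the limits of compound 1 and compound 2 together with the limit of compound 3. Compound 4 is therefore estimated at 100000 nM, with a plausible range from 40000 nM to 300000 nM, and most likely the assay will again report only a limit.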

Compound 4, concentration for 50% growth inhibition: > 100000 nM
Compound 4 ended at the assay's limit; the forecaster's own chance of this, stated with the estimate: 85%; the middle value lies on the limit itself.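

In this assay compound 4 gives > 100000 nM and this is a limit of the assay, not a number. Compound 3 and compound 4 both rest on limits, so the step between them cannot be read. The compounds shown leave open how strongly any of them inhibits growth, and whether benzyl in place of phenyl on a nitrogen on an aromatic ring changes that at all.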